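Swapping the pyridine on the amide of compound 3

The compounds below may be only part of what the source reports. "The series", "measured", "known", "first", "only" and "open" are said of these compounds alone.

In a functional assay on the whole organism (blood) with Rattus norvegicus as the target, with stated times of 24 h and 1 h, at a dose of 5 mg/kg by the intraperitoneal route (a higher number here means a stronger effect of the compound at the dose given, a lower number a weaker effect), compound 1 `COc1ccc(Cl)cc1C(=O)NCCC1CCN(S(=O)(=O)NC(=O)NC[C@@H]2C[C@@H]3C=C[C@@H]2C3)CC1` gives 37%, compound 2 `O=C(NC[C@@H]1C[C@@H]2C=C[C@@H]1C2)NS(=O)(=O)N1CCC(CCNC(=O)C(F)(F)F)CC1` gives 22%, and compound 3 `Cc1cccc(C(=O)NCCC2CCN(S(=O)(=O)NC(=O)NC[C@@H]3C[C@@H]4C=C[C@@H]3C4)CC2)n1` gives 20%. Compound 3 thus has the lowest of the three numbers, but its gap to compound 2 is within the scatter, as the step of a number 2 percentage points lower from compound 2 to compound 3 (within the scatter) shows, while compound 1 stands clearly higher, as the step of a number 17 percentage points lower from compound 1 to compound 3 (beyond the scatter) shows. Compound 4 `COc1ccc(C(=O)NCCC2CCN(S(=O)(=O)NC(=O)NC[C@@H]3C[C@@H]4C=C[C@@H]3C4)CC2)cn1` differs from compound 3 in one place: 6-methoxypyridin-3-yl in place of 6-methylpyridin-2-yl on a carbonyl carbon. Among the measured compounds shown here, no measured step changes one pyridine for another, so nothing bears directly on this change. For the measured compounds named here, the only step between two aromatic groups on this carbonyl carbon is a number 17 percentage points lower from compound 1 to compound 3 (beyond the scatter), where the aromatic group carrying a methoxy group gave the higher number. On that slim basis a small upward step is expected for compound 4, namely a number 7 percentage points higher from compound 3 to compound 4 (within the scatter), though it could well stay within the scatter. Compound 4 is therefore estimated at 27% in this assay, with a range from 12% to 42%.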

Compound 4, a percentage reported as activity, at one dose (the size of the read-out at that dose, not a potency): 11%
Beside the measured number, compound 4's estimate is 16 percentage points above it, and the stated range ends above it.
By their numbers in this assay, from the lowest: compounds 4, 3 and 2 (each within the scatter of the next, the first and the last beyond it); then compound 1.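

Exchanging 6-methylpyridin-2-yl for 6-methoxypyridin-3-yl on this carbonyl carbon has no readable effect in this assay: the assay gives a number 9 percentage points lower from compound 3 to compound 4 (within the scatter) and so cannot tell these two pyridines apart. A methoxy group on the aromatic ring does not by itself go with a high number, as shown by a number 26 percentage points lower from compound 1 to compound 4 (beyond the scatter) in this series, and the new pyridine also falls clearly short of the non-aromatic trifluoromethyl group, as shown by a number 11 percentage points lower from compound 2 to compound 4 (beyond the scatter) here. No measurement shown explains these differences.

Whether the chloro or the methoxy group of compound 1 matters more stays open, as no compound shown carries only one of them on a phenyl ring. Also open, from the compounds shown here alone, is how an amine or a carboxylic acid on the pyridine ring would read.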